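Pyridin-4-yl to pyridin-2-yl in compound 4

The source may report more compounds than this note shows. Statements on the series, on what has been measured and on what is new or still open speak of the compounds shown alone.

Compound 1 `CCCCCCCCc1ccc(OCC(=O)Cn2ncnn2)cc1` gives < 5% (a limit)
Compound 2 `CCCCCCCCc1ccc(OCC(=O)Cn2nnc(-c3cccc(S(=O)(=O)N(C)C)c3)n2)cc1` gives 9% (a number)
Compound 3 `CCCCCCCCc1ccc(OCC(=O)Cn2nnc(-c3ccncc3)n2)cc1` gives < 5% (a limit)

In an ADME assay on S9 fraction from liver (Rattus norvegicus) for metabolic stability, read by LC-MS, using NADPH, with a stated time of 30 min (a lower number here means that less of the compound is left, a higher number that more of the compound is left), compound 3 gives < 5% as a limit of the assay, not a number. Compound 3 thus stands at the limit of < 5% in this assay, at which 2 of the 3 values shown sit, and has no exact value. Compound 4 `CCCCCCCCc1ccc(OCC(=O)Cn2nnc(-c3ccccn3)n2)cc1` has the same atoms joined differently, with pyridin-2-yl in place of pyridin-4-yl on an aromatic carbon. The nearest measured steps are a number at least 4 percentage points lower from compound 2 to compound 3 (that floor lies within the scatter) on putting pyridin-4-yl in place of 3-(dimethylsulfamoyl)phenyl, and a step that the two limits leave unreadable from compound 1 to compound 3 on adding pyridin-4-yl to the shared core. Neither step compares the two pyridinyl groups. The estimated change is a step that the limit leaves unreadable from compound 3 to compound 4 and no step beyond the scatter is expected. The expected value for compound 4 is 4% (estimated range 1% to 10%).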

Compound 4, percent of the compound remaining: 30%
Estimate against measurement, compound 4: 26 percentage points below; the measured number lies above the stated range.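

Among the compounds shown here, with the same atoms joined differently, pyridin-2-yl in place of pyridin-4-yl on the aromatic carbon of the five-membered ring gives a number at least 25 percentage points higher from compound 3 to compound 4 (beyond the scatter) in this assay, so the way the pyridine is joined matters here, which the earlier compounds could not show. The same group also gives a number 21 percentage points higher from compound 2 to compound 4 (beyond the scatter) and a number at least 25 percentage points higher from compound 1 to compound 4 (beyond the scatter). Two of these three steps are floors, not full sizes, set by a limit: the limit of < 5% in this assay, at which 2 of the 4 values shown sit.

The compounds shown give no cause for the step. They also leave open how pyridin-3-yl or pyrimidin-2-yl would behave at this position, and whether the step would hold with a shorter chain on the shared core.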